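Compound 2 to compound 3 on the aromatic nitrogen

A few compounds are considered here, and "the series" means these few. Any claim that something is new, unique, unknown or untested is made for them only; others in the source may bear on it.

Values so far in a functional assay on MCF7 cells (Homo sapiens) for cytotoxicity, read by MTT assay, with a stated time of 96 h (on this read-out higher numbers stand for weaker inhibition and lower numbers for stronger inhibition), are these
- compound 1 (`COc1cc(C(=O)c2cn(-c3ccccc3N)cc2-c2ccccc2)cc(OC)c1OC`) at 3800 nM
- compound 2 (`COc1cccc(-n2cc(C(=O)c3cc(OC)c(OC)c(OC)c3)c(-c3ccccc3)c2)c1`) at 500 nM

Compound 2 holds the lower of the two numbers. Compound 3 (`COc1cc(C(=O)c2cn(-c3ccc([N+](=O)[O-])cc3)cc2-c2ccccc2)cc(OC)c1OC`) is still unmeasured and carries 4-nitrophenyl in place of 3-methoxyphenyl on the same aromatic nitrogen (4-nitrophenyl in place of 3-methoxyphenyl on an aromatic nitrogen). For the measured compounds named here, one measured step bears on this place (a 7.6-fold lower number from compound 1 to compound 2 (0.88 log units; beyond the scatter)), a modest one that exchanged 2-aminophenyl for 3-methoxyphenyl. Neither measured compound has a 4-nitrophenyl group, so that step gives a scale but no firm direction. With compound 2 at the low end (500 nM), a change of similar or smaller size toward a higher number is expected in this assay. The expected step is a 2.6-fold higher number from compound 2 to compound 3 (0.41 log units; beyond the scatter) on this reasoning. The estimated value for compound 3 is 1300 nM with an expected range from 300 nM to 5000 nM in this assay.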

Compound 3, half-maximal inhibitory concentration: 4000 nM
For compound 3 the middle estimate is 3.1-fold (0.49 log units) below the measured one; the measured number falls inside the stated range.
By their numbers in this assay, from the lowest: compound 2; then compounds 1 and 3 (each within the scatter of the next).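

On the aromatic nitrogen, 4-nitrophenyl in place of 3-methoxyphenyl gives an 8.0-fold higher number from compound 2 to compound 3 (0.90 log units; beyond the scatter) in this assay, so the step seen earlier now has a direction from a second group: both other aryl groups stand on the high side of compound 2. Against 2-aminophenyl, 4-nitrophenyl gives a 1.1-fold higher number from compound 1 to compound 3 (0.02 log units; within the scatter), which places these two differently substituted phenyl groups level with each other. Among the three compounds, only 3-methoxyphenyl gives the lower number (nothing available explains this difference).

In each of these steps the substituent and its place on the phenyl ring change together, so the contribution of each cannot be separated. Going by these compounds, how an unsubstituted phenyl group, or a phenyl group carrying a carboxylic acid or a longer alkyl chain, would read on this nitrogen remains open.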